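This account rests on a few compounds, and the source may have more. Where it says the series, first, only, none or still open, it means among the compounds named here.

Measured so far in an ADME assay on microsomes from liver (Rattus norvegicus) for metabolic stability, read by LC-MS, using NADPH, at 37 degrees C; a higher number here means that the compound lasts longer, a lower number that the compound disappears faster:
compound 1 `Cc1oc(-c2ccccc2Cl)nc1CN1CCC(C(=O)NCCCN2C[C@H](C)C[C@H](C)C2)CC1` gives 0.25 h as a number
compound 2 `Cc1oc(-c2ccc(Cl)cc2)nc1CN1CCC(C(=O)NCCCN2C[C@H](C)C[C@H](C)C2)CC1` gives > 0.5 h as a limit
compound 3 `Cc1ccccc1-c1nc(CN2CCC(C(=O)NCCCN3CCCCC3)CC2)c(C)o1` gives > 0.5 h as a limit

Compound 2 stands at a limit and not at a number: the limit of > 0.5 h in this assay, at which 2 of the 3 values shown sit, applies to it.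

The next compound is compound 4 (`Cc1oc(-c2ccc(Cl)c(Cl)c2)nc1CN1CCC(C(=O)NCCCN2C[C@H](C)C[C@H](C)C2)CC1`), and the change from compound 2 is chloro in place of hydrogen on an aromatic carbon (4-chlorophenyl to 3,4-dichlorophenyl). The measured step that leads to compound 2 is an at least 2.0-fold higher number from compound 1 to compound 2 (0.30 log units; that floor lies within the scatter) (2-chlorophenyl to 4-chlorophenyl). That step adds no chloro in place of hydrogen, so it sets no size for this change. No step beyond the scatter is therefore expected in this assay and no direction is claimed. The estimate amounts to an expected at least 1.1-fold lower number from compound 2 to compound 4 (0.04 log units; that floor lies within the scatter) and nothing more. For compound 4 the expected half-life is 0.45 h with an estimated range from 0.2 h to 1 h.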

Compound 4, half-life: > 0.5 h
Compound 4 ended at the assay's limit; the forecaster's own chance of this, stated with the estimate: 45%; at least 1.1-fold (0.04 log units) between middle value and limit.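

In this assay compound 4 gives > 0.5 h, a limit and not a number. Adding a chloro ortho to the existing chloro therefore leaves the compound at the assay's limit, but the step from compound 2 cannot be read, because both values are limits: the limit of > 0.5 h in this assay, at which 3 of the 4 values shown sit.

Going by these compounds alone, the one readable step is an at least 2.0-fold higher number from compound 1 to compound 4 (0.30 log units; that floor lies within the scatter), so 3,4-dichlorophenyl is not separated from 2-chlorophenyl beyond the scatter.

From the compounds shown here alone, the half-lives of compound 2 and compound 4 as numbers remain open, and with them any size or direction for this chloro. Going by these compounds, it is also open whether a methoxy group or a nitrile in place of the added chloro would give a readable number in this assay.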